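Thiophene for dimethylphenyl on the vinyl carbon of compound 1

This account rests on a few compounds, and the source may have more. Where it says the series, first, only, none or still open, it means among the compounds named here.

Going by the values given here, compound 1 `Cc1ccc(S/C(=C/c2cc(C)cc(C)c2)C(=O)c2ccc(Cl)cc2)cc1` gives 50000 nM in a functional assay on DU-145 cells (Homo sapiens) for inhibition, read by trypan blue exclusion, with a stated time of 96 h (on this read-out higher numbers stand for weaker inhibition of growth and lower numbers for stronger inhibition of growth), the highest of the three numbers known. Compound 2 `Cc1cc(C)cc(/C=C(/Sc2ccc(Br)cc2)C(=O)c2ccc(Cl)cc2)c1` gives 10000 nM and compound 3 `Cc1cc(C)cc(/C=C(/SCc2ccc(Cl)cc2)C(=O)c2ccc(Cl)cc2)c1` gives 10000 nM; the steps of a 5.0-fold lower number from compound 1 to compound 2 (0.70 log units; beyond the scatter) and a 5.0-fold lower number from compound 1 to compound 3 (0.70 log units; beyond the scatter) change only the group on the sulfur, and no change at the digits printed from compound 2 to compound 3 (within the scatter). Compound 4 `Cc1ccc(S/C(=C/c2sccc2C)C(=O)c2ccc(Cl)cc2)cc1` differs from compound 1 elsewhere: 3-methylthiophen-2-yl in place of 3,5-dimethylphenyl on a double-bonded chain carbon bound to a double-bonded chain carbon. Among the compounds with values here, no measured step touches the group on the double-bonded chain carbon, so the known steps give no direction for this change. The expectation for compound 4 is therefore a step of no change at the digits printed from compound 1 to compound 4 (within the scatter) that stays within the scatter, with the estimate for compound 4 set at 50000 nM and the range 15000 nM to 150000 nM.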

Compound 4, concentration for 50% growth inhibition: 50000 nM
Beside the measured number, compound 4's estimate shows no gap at the digits printed; the measured number falls inside the stated range.
By their numbers in this assay, from the lowest: compounds 2 and 3 (each within the scatter of the next); then compounds 1 and 4 (each within the scatter of the next).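

In this assay, going by these compounds alone, the double-bonded chain carbon, untouched by the earlier compounds, now has its first reading: 3-methylthiophen-2-yl in place of 3,5-dimethylphenyl gives no change at the digits printed from compound 1 to compound 4 (within the scatter) and leaves the number where it was. For this single pair, a five-membered aromatic ring with a hetero atom and a six-membered carbon ring cannot be told apart by this read-out. No measured information bears on why the step is flat.

On these data alone, whether the bromo and 4-chlorobenzyl changes that lowered the number from compound 1 would do the same on compound 4 remains open. So does the effect of a group carrying an amine or a carboxylic acid on the double-bonded chain carbon.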